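Amine variation on the shared core: compound 4

This account rests on a few compounds, and the source may have more. Where it says the series, first, only, none or still open, it means among the compounds named here.

Of the compounds shown here, three have been measured in an assay on cell membranes for displacement of a labelled ligand from corticotropin-releasing factor receptor 1 (Rattus norvegicus); a lower number here means a stronger inhibitor, a higher number a weaker inhibitor. Compound 1 `CCCN(CCC)c1nc(C)nc2c(-c3c(C)cc(N(C)C)nc3C)c(C)nn12` gives 14.9 nM; compound 2 `CCCCN(C)c1nc(C)nc2c(-c3ccc(OC)nc3C)c(C)nn12` gives 8.1 nM; compound 3 `CCCN(CC1CC1)c1nc(C)nc2c(-c3ccc(OC)nc3C)c(C)nn12` gives 1.6 nM, the lowest of the three numbers, with compound 2 nearest and compound 1 furthest. Compound 4 `CCN(CC)c1nc(C)nc2c(-c3ccc(OC)nc3C)c(C)nn12` has not yet been measured. The change is diethylamino in place of (cyclopropylmethyl)(propyl)amino on an aromatic carbon. Among the measured compounds shown here, the only step bearing on this place is a 5.1-fold lower number from compound 2 to compound 3 (0.70 log units; beyond the scatter). Because a 5.1-fold lower number from compound 2 to compound 3 (0.70 log units; beyond the scatter) went with a larger amine at this place, and diethylamino is the smallest of the three amines seen there, a higher number is expected for compound 4, though short of a full reversal of that step. The estimate for compound 4 in this assay is 5 nM, range 2 nM to 15 nM. This means an expected step of a 3.1-fold higher number from compound 3 to compound 4 (0.49 log units; beyond the scatter).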

Compound 4, half-maximal inhibitory concentration: 12 nM
Estimate against measurement, compound 4: 2.4-fold (0.38 log units) below; measured number inside the range.
By their numbers in this assay, from the lowest: compound 3; then compounds 2, 4 and 1 (each within the scatter of the next).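

In this assay, the loss of (cyclopropylmethyl)(propyl)amino costs a 7.5-fold higher number from compound 3 to compound 4 (0.88 log units; beyond the scatter), while diethylamino and butyl(methyl)amino stay level, with a 1.5-fold higher number from compound 2 to compound 4 (0.17 log units; within the scatter). Among these three amines on the shared core, only (cyclopropylmethyl)(propyl)amino therefore stands apart, and the earlier step alone could not show that the other two sit level. No measurement here accounts for this difference.

On these data alone, it remains open whether the three-membered ring itself matters or only the overall size of the amine. Butyl(propyl)amino at this place on the same core would bear on that question.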